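The source may hold more compounds than are shown below. What is called first, only, known or untested is meant among the compounds shown, and "the series" means these compounds.

Three compounds share one core and differ only in the group on an aromatic nitrogen of the five-membered ring. Compound 1 `CN1C(=S)[C@@H](NC(=O)c2nc(Cc3ccccc3)n(CCC(F)(F)F)n2)COc2ccccc21` carries a 3,3,3-trifluoropropyl group there, and in a functional assay on HT-29 cells (Homo sapiens) for inhibition, read by luminescence and CellTiter-Glo, with a stated time of 24 h (on this read-out lower numbers stand for an effect already at smaller amounts and higher numbers for an effect only at larger amounts of compound), compound 1 gives 1550 nM. Compound 2 `CN1C(=S)[C@@H](NC(=O)c2nc(Cc3ccccc3)n(C3CCCCC3)n2)COc2ccccc21` carries a cyclohexyl group, and in this assay compound 2 gives 4000 nM. Compound 3 `CN1C(=S)[C@@H](NC(=O)c2nc(Cc3ccccc3)n(C3COC3)n2)COc2ccccc21` carries an oxetan-3-yl group, and in this assay compound 3 gives 916 nM, the lowest of the three numbers, though its gap to compound 1 is within the scatter. The steps show a 4.4-fold lower number from compound 2 to compound 3 (0.64 log units; beyond the scatter) and a 1.7-fold lower number from compound 1 to compound 3 (0.23 log units; within the scatter).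

Compound 4 `CN1C(=S)[C@@H](NC(=O)c2nc(Cc3ccccc3)n(C3CCNCC3)n2)COc2ccccc21` differs from compound 3 in one place: piperidin-4-yl in place of oxetan-3-yl on an aromatic nitrogen. The step from the cyclohexyl compound bears most on this change, since piperidin-4-yl is also a six-membered ring, and it ran a 4.4-fold lower number from compound 2 to compound 3 (0.64 log units; beyond the scatter). Within the data shown here, the ring nitrogen adds a hydrogen-bond donor, for which no measured step gives guidance. A modest rise in the number is therefore expected, estimated as a 2.0-fold higher number from compound 3 to compound 4 (0.29 log units; within the scatter). Compound 4 is expected to give 1800 nM, with a range from 600 nM to 5500 nM.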

Compound 4, half-maximal effective concentration: 1000 nM
Beside the measured number, compound 4's estimate is 1.8-fold (0.26 log units) above it; the measured number falls inside the stated range.
By their numbers in this assay, from the lowest: compounds 3, 4 and 1 (each within the scatter of the next); then compound 2.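

In this assay, the piperidin-4-yl group cannot be told apart from the oxetan-3-yl group (a 1.1-fold higher number from compound 3 to compound 4 (0.04 log units; within the scatter)) or from the 3,3,3-trifluoropropyl group (a 1.6-fold lower number from compound 1 to compound 4 (0.19 log units; within the scatter)), so this aromatic nitrogen tolerates a larger ring that carries a hydrogen-bond donor. The comparison with a ring of the same size is more telling: with a 4.0-fold lower number from compound 2 to compound 4 (0.60 log units; beyond the scatter), exchanging one ring carbon of the cyclohexyl group for nitrogen gives a step beyond the scatter, and compound 2 alone stands apart among the four compounds. No measurement at hand explains either result.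

Still open, from the compounds shown here alone, is how a methyl group on the ring nitrogen of the piperidin-4-yl group, or a longer chain ending in an amine or a carboxylic acid, would fare at this position. A smaller all-carbon ring such as cyclobutyl would show whether the higher number of compound 2 extends beyond the cyclohexyl group.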